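Morpholine in Place of Dimethylamino on an Inactive Ketoamide

This account rests on a few compounds, and the source may have more. Where it says the series, first, only, none or still open, it means among the compounds named here.

Of the compounds shown here, three have so far been tested in an assay on HEK-293T cells for inhibition of phospholipase A and acyltransferase 2 (Homo sapiens), with stated times of 30 min and 20 min; a lower number here means a stronger inhibitor, a higher number a weaker inhibitor. Compound 1 `O=C(NCc1ccccc1)C(F)(F)C(O)CCc1ccccc1` gives only a limit of the assay, > 10000 nM. Compound 2 `O=C(CCc1ccc(Cl)cc1)C(=O)N1CCCCC1` likewise gives only a limit, > 10000 nM. Compound 3 `CN(C)C(=O)C(=O)CCc1ccc(Cl)cc1` also stands at a limit, > 10000 nM, so its place among the numbers shown is simply at the edge of what this assay reports. For the measured compounds named here, the one step between measured compounds, a step that the two limits leave unreadable from compound 2 to compound 3, cannot be read because both of its ends sit at the limit of > 10000 nM in this assay, at which 3 of the 3 values shown sit. Compound 4 `O=C(CCc1ccc(Cl)cc1)C(=O)N1CCOCC1` differs from compound 3 by morpholin-4-yl in place of dimethylamino on a carbonyl carbon. Going by the values given here, no measured step bears readably on this change: the only step that touches the same carbonyl carbon, a step that the two limits leave unreadable from compound 2 to compound 3, has no readable size, and no other pair shares such an amide change. Compound 4 is therefore expected to show a step that the limit leaves unreadable from compound 3 to compound 4, which is within the scatter, and most likely to give another limit. The estimate for compound 4 in this assay is 20000 nM, with a range from 8000 nM to 60000 nM.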

Compound 4, half-maximal inhibitory concentration: > 10000 nM
Compound 4 ended at the assay's limit; the forecaster's own chance of this, stated with the estimate: 85%; the middle value lies beyond the limit too.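

Neither step to compound 4, from compound 2 or from compound 3, can be read in this assay at all, and the reason is the same for both: the limit of > 10000 nM in this assay, at which 4 of the 4 values shown sit. The compounds shown leave open how the amide groups on this core rank against one another, and which change, if any, would give a value short of the limit.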